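Sulfonyl substituent changes on a shared urea core

A few compounds are considered here, and "the series" means these few. Any claim that something is new, unique, unknown or untested is made for them only; others in the source may bear on it.

Measured compounds:
Compound 1, `O=C(NCc1ccc(S(=O)(=O)c2cc(F)cc(F)c2)cc1)N1Cc2ccncc2C1`: 7.1 nM
Compound 2, `CC(=O)N1CCC(S(=O)(=O)c2ccc(CNC(=O)N3Cc4ccncc4C3)cc2)CC1`: 83 nM
Compound 3, `CN1CCC(S(=O)(=O)c2ccc(CNC(=O)N3Cc4ccncc4C3)cc2)CC1`: 48 nM

In an assay on isolated protein for inhibition of Nicotinamide phosphoribosyltransferase (Homo sapiens), read by mass spectrometry, with stated times of 15 min and 30 min (on this read-out higher numbers stand for weaker inhibition and lower numbers for stronger inhibition), compound 3 gives 48 nM, the second highest number of the three. Its nearest neighbour is compound 2, separated by a 1.7-fold lower number from compound 2 to compound 3 (0.24 log units; within the scatter), a gap within the scatter; compound 1 lies furthest away, with a 6.8-fold higher number from compound 1 to compound 3 (0.83 log units; beyond the scatter).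

Compound 4, `O=C(NCc1ccc(S(=O)(=O)N2CCC(N3CCCC3)CC2)cc1)N1Cc2ccncc2C1`, has not yet been measured. It differs from compound 3 by 4-(pyrrolidin-1-yl)piperidin-1-yl in place of 1-methylpiperidin-4-yl on a sulfonyl sulfur. Among the measured compounds shown here, the steps that bear on this change are those that already swapped the group on the sulfonyl sulfur: a 12-fold higher number from compound 1 to compound 2 (1.07 log units; beyond the scatter) and a 6.8-fold higher number from compound 1 to compound 3 (0.83 log units; beyond the scatter) both weakened the number, while a 1.7-fold lower number from compound 2 to compound 3 (0.24 log units; within the scatter) stayed within the scatter. From the compounds shown here alone, none of these steps places a nitrogen on the sulfonyl sulfur, so the new arrangement is untested. On this basis compound 4 is expected to stay near compound 3, with a 1.3-fold higher number from compound 3 to compound 4 (0.10 log units; within the scatter) judged to fall within the scatter. Compound 4 is therefore estimated at 60 nM, with a range of 20 nM to 200 nM.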

Compound 4, half-maximal inhibitory concentration: 7.4 nM
For compound 4 the middle estimate is 8.1-fold (0.91 log units) above the measured one; measured number outside the range, below it.
By their numbers in this assay, from the lowest: compounds 1 and 4 (each within the scatter of the next); then compounds 3 and 2 (each within the scatter of the next).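

In this assay, 4-(pyrrolidin-1-yl)piperidin-1-yl on the sulfonyl sulfur gives a 6.5-fold lower number from compound 3 to compound 4 (0.81 log units; beyond the scatter) and also an 11-fold lower number from compound 2 to compound 4 (1.05 log units; beyond the scatter), which shows that a non-aromatic group at this place need not carry the weaker numbers seen with the two piperidin-4-yl groups. Set against the 3,5-difluorophenyl group, the same change gives a 1.0-fold higher number from compound 1 to compound 4 (0.02 log units; within the scatter), so among these compounds an aromatic ring on the sulfonyl sulfur is not needed to reach this level of inhibition. Nothing given here accounts for the size of these steps.

The compounds shown do not separate the nitrogen on the sulfonyl sulfur from the added pyrrolidin-1-yl ring as the source of the change. Also open, from the compounds shown here alone, is how a morpholine ring, a dimethylamine or a carboxylic acid in place of that pyrrolidin-1-yl ring would read.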